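This account rests on a few compounds, and the source may have more. Where it says the series, first, only, none or still open, it means among the compounds named here.

Compound 1 `Cc1nnc(SCC(=O)N/N=c2/scc(-c3ccccc3)n2-c2ccccc2)s1` in a functional assay on C6 cells (Rattus norvegicus) for cytotoxicity, read by MTT assay, with a stated time of 24 h, tested at 25 ug/mL; a lower number here means a stronger effect, a higher number a weaker effect of the compound at the concentration tested: 65.9%
Compound 2 `Cn1cnnc1SCC(=O)N/N=c1/scc(-c2ccc(C#N)cc2)n1-c1ccccc1` in this assay: 58.8%

In this assay compound 1 gives 65.9% and compound 2 gives 58.8%. The number for compound 2 is the lower of the two, but the gap to compound 1 lies within the scatter, so the two cannot be told apart. Compound 3 `Cn1cnnc1SCC(=O)N/N=c1/scc(-c2ccccc2)n1-c1ccccc1` differs from compound 2 in one place: hydrogen in place of cyano on an aromatic carbon. Within the data shown here, no measured pair shows a step of this kind, so no step beyond the scatter is expected in this assay in either direction. Compound 3 is therefore expected at 63%, with a range from 50% to 76%. The estimated step of a number 4.2 percentage points higher from compound 2 to compound 3 (within the scatter) is expected to stay within the scatter.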

Compound 3, a percentage reported as activity, at one concentration (the size of the read-out at that concentration, not a potency): 77.3%
Estimate against measurement, compound 3: 14.3 percentage points below; the measured number lies above the stated range.
By their numbers in this assay, from the lowest: compounds 2 and 1 (each within the scatter of the next); then compound 3.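

Cyano on this aromatic carbon matters in this assay: hydrogen in its place gives a number 18.5 percentage points higher from compound 2 to compound 3 (beyond the scatter) and so a weaker effect at the concentration tested. The group on the sulfur matters as well, since 4-methyl-4H-1,2,4-triazol-3-yl in place of 5-methyl-1,3,4-thiadiazol-2-yl gives a number 11.4 percentage points higher from compound 1 to compound 3 (beyond the scatter) with the phenyl unchanged. No measurement at hand accounts for either step.

On these data alone, whether cyano has the same effect with 5-methyl-1,3,4-thiadiazol-2-yl on the sulfur remains open. So does the outcome with a methoxy group, an amine or a carboxylic acid on this aromatic carbon.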